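The source may hold more compounds than are shown below. What is called first, only, known or untested is meant among the compounds shown, and "the series" means these compounds.

Going by the values given here, in a functional assay (Cavia porcellus) for antagonist activity at Serotonin 3 (5-HT3) receptor (Homo sapiens) (a higher number here means a weaker inhibitor, a lower number a stronger inhibitor), compound 1 `Cc1[nH]cnc1CN1CCN(c2cccc(Cl)c2)C1=O` gives 12 nM, the highest of the two numbers so far; compound 2 `Cc1[nH]cnc1CN1CCN(c2cc(Cl)cc(Cl)c2)C1=O` gives 5.62 nM. The step of a 2.1-fold lower number from compound 1 to compound 2 (0.33 log units; beyond the scatter) is the only measured one that bears on the change to compound 3 `Cc1[nH]cnc1CN1CCN(c2ccccc2)C1=O`: hydrogen in place of chloro on an aromatic carbon, on an aromatic carbon meta to a large group. Among the compounds with values here, since adding a chloro carried compound 1 to compound 2 with a modest lower number, removing the single chloro of compound 1 is expected to run the other way, as a modest rise of a 2.1-fold higher number from compound 1 to compound 3 (0.32 log units; beyond the scatter). Compound 3 is therefore estimated at 25 nM, in the range 10 nM to 60 nM.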

Compound 3, antagonist equilibrium constant: 26.9 nM
Compound 3: the middle estimate sits 1.1-fold (0.03 log units) below what was measured; measured number inside the range.
By their numbers in this assay, from the lowest: compound 2; then compound 1; then compound 3.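

In this assay, hydrogen in place of chloro gives a 2.2-fold higher number from compound 1 to compound 3 (0.35 log units; beyond the scatter), so the chloro already present in compound 1 also counts, not only the second chloro added in a 2.1-fold lower number from compound 1 to compound 2 (0.33 log units; beyond the scatter). Across these two single changes, the number falls with chloro in place of hydrogen on an aromatic carbon, and no compound shown goes against this. Nothing measured here gives a reason for this trend. Still open, as far as these compounds go, is whether a fluoro, methyl or nitrile on that carbon would act like chloro. Also open, from the compounds shown here alone, is how chloro would act on the other carbons of the six-membered aromatic ring.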